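Moving from pyrimidin-4-yl to 3-methyl-1,2-thiazol-5-yl

The source may report more compounds than this note shows. Statements on the series, on what has been measured and on what is new or still open speak of the compounds shown alone.

In a functional assay for activation of Alpha-1B adrenergic receptor (Homo sapiens), read by calcium flux (on this read-out higher numbers stand for an effect only at larger amounts of compound and lower numbers for an effect already at smaller amounts), compound 1 `c1ccc(-c2cnccn2)c(OCC2=NCCN2)c1` gives 631 nM. Compound 2 `c1ccc(-c2ccncn2)c(OCC2=NCCN2)c1` shows only a limit there, < 100000 nM. Compound 3 `Cc1ccoc1-c1ccccc1OCC1=NCCN1` likewise shows only a limit, < 100000 nM. So compound 2 stands at the edge of what this assay reports, and the step that the limit leaves unreadable from compound 1 to compound 2, the step that the limit leaves unreadable from compound 1 to compound 3 and the step that the two limits leave unreadable from compound 2 to compound 3 cannot be sized, because of the limit of < 100000 nM in this assay, at which 2 of the 3 values shown sit. Compound 4 `Cc1cc(-c2ccccc2OCC2=NCCN2)sn1` carries 3-methyl-1,2-thiazol-5-yl in place of pyrimidin-4-yl on an aromatic carbon. Among the measured compounds shown here, no measured step reads out the effect of this change; the only comparable compound, compound 3, also sits at the limit. The step from compound 2 is therefore expected to be a step that the limit leaves unreadable from compound 2 to compound 4, with compound 4 estimated in this assay at 30000 nM, between 3000 nM and 100000 nM.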

Compound 4, half-maximal effective concentration: < 100000 nM
Compound 4: only a limit was reported; the forecaster's own chance of this, stated with the estimate: 65%; the middle value lies beyond the limit too.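

The steps from compound 1, compound 2 and compound 3 to compound 4 cannot be read in this assay, since compound 4 also gives only a limit: the limit of < 100000 nM in this assay, at which 3 of the 4 values shown sit.

The compounds shown leave open how far compound 2, compound 3 and compound 4 lie from compound 1, and whether they differ from one another.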